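The source may hold more compounds than are shown below. What is called first, only, known or untested is meant among the compounds shown, and "the series" means these compounds.

Measured compounds:
compound 1 (`Cc1cc(-c2ccc(C#N)c(C#N)c2)ccc1Oc1cc(N)nc(Nc2ccc(C#N)cc2)n1`): 76700 nM in a toxicity assay on MT4 cells (Homo sapiens) for cytotoxicity, read by MTT assay; on this read-out higher numbers stand for lower toxicity in this test and lower numbers for higher toxicity in this test
compound 2 (`Cc1cc(-c2cccc(Cl)c2)cc(C)c1Oc1cc(N)nc(Nc2ccc(C#N)cc2)n1`): 22300 nM in this assay

Compound 2 stands lowest of the two numbers in this assay; the nearest number, that of compound 1, is higher by a gap beyond the usual scatter. The two compounds differ in more than one place, so only the two values themselves can be set side by side, and no single change can be credited with the gap.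

Compound 3, `Cc1cc(-c2ccc(C#N)c(F)c2)cc(C)c1Oc1cc(N)nc(Nc2ccc(C#N)cc2)n1`, has not yet been measured. It differs from compound 2 in one place: 4-cyano-3-fluorophenyl in place of 3-chlorophenyl on an aromatic carbon.

Compound 3 is expected to show a step of a 1.8-fold higher number from compound 2 to compound 3 (0.25 log units; within the scatter) upward in this assay, a moderate rise beyond the scatter, since compound 1, which also bears a nitrile, gives 76700 nM. Compound 3 is therefore estimated at 40000 nM, with a range from 15000 nM to 100000 nM.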

Compound 3, half-maximal cytotoxic concentration: 5000 nM
Estimate against measurement, compound 3: 8.0-fold (0.90 log units) above; measured number outside the range, below it.
By their numbers in this assay, from the lowest: compound 3; then compound 2; then compound 1.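

Going by these compounds alone, the exchange of 3-chlorophenyl for 4-cyano-3-fluorophenyl gives the first single change that can be read at this position, and in this assay it brings a 4.5-fold lower number from compound 2 to compound 3 (0.65 log units; beyond the scatter) and so higher toxicity in this test. The place on the aromatic carbon, meta to two methyl groups, is therefore not indifferent to the group it carries, and here the group with the nitrile and the fluorine goes with the lower number. Nothing in the data given accounts for this step.

Going by these compounds, the nitrile and the fluorine enter together as the chlorine leaves, so the share of each in the step stays open. On these data alone, how an unsubstituted phenyl, a 4-cyanophenyl or a phenyl bearing an amine or a carboxylic acid would stand at this place also remains open.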